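The compounds below may be only part of what the source reports. "The series", "measured", "known", "first", "only" and "open" are said of these compounds alone.

Three compounds with the same core differ only in the aryl group on an aromatic nitrogen. In a functional assay on Huh-7 cells (Homo sapiens) for cytotoxicity, read by cell counting, with a stated time of 48 h (a higher number here means a weaker inhibitor, a lower number a stronger inhibitor), compound 1 `Clc1ccc(-n2cc(COc3cccc4cnc(Nc5cccc(Cl)c5)nc34)nn2)cc1` gives 24000 nM, compound 3 `COc1cccc(-n2cc(COc3cccc4cnc(Nc5cccc(Cl)c5)nc34)nn2)c1` gives 23000 nM, and compound 2 `COc1ccccc1-n1cc(COc2cccc3cnc(Nc4cccc(Cl)c4)nc23)nn1` gives 7000 nM, the lowest number of the three. Compound 4 `Clc1cccc(Nc2ncc3cccc(OCc4cn(-c5cc(Cl)cc(Cl)c5)nn4)c3n2)c1` keeps the core of compound 2 and changes one group: 3,5-dichlorophenyl in place of 2-methoxyphenyl on an aromatic nitrogen.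

The measured steps suggest how much this group can matter. They show a 3.4-fold lower number from compound 1 to compound 2 (0.54 log units; beyond the scatter) and a 3.3-fold higher number from compound 2 to compound 3 (0.52 log units; beyond the scatter), both modest, whereas a 1.0-fold lower number from compound 1 to compound 3 (0.02 log units; within the scatter) is within the scatter. So 4-chlorophenyl and 3-methoxyphenyl sit at the same level, and compound 2, with its 2-methoxyphenyl group, is the only one that stands apart. Within the data shown here, with three compounds this is a thin basis, but it suggests that losing the 2-methoxyphenyl group will bring compound 4 back towards the level of compound 1 and compound 3, although no compound measured so far carries the 3,5-dichlorophenyl group.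

The expected change is a 2.9-fold higher number from compound 2 to compound 4 (0.46 log units; beyond the scatter), a modest rise in the number. Compound 4 is estimated at 20000 nM, with an expected range from 9000 nM to 45000 nM.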

Compound 4, half-maximal inhibitory concentration: 7000 nM
Estimate against measurement, compound 4: 2.9-fold (0.46 log units) above; the whole stated range lies above it.
By their numbers in this assay, from the lowest: compounds 2 and 4 (each within the scatter of the next); then compounds 3 and 1 (each within the scatter of the next).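

In this assay, the low level is no longer tied to the 2-methoxyphenyl group: replacing it with 3,5-dichlorophenyl, which has two chlorine atoms and no oxygen, gives no change at the digits printed from compound 2 to compound 4 (within the scatter) and so leaves the level in place. Compound 4 also keeps the gap to the other two, with a 3.3-fold lower number from compound 3 to compound 4 (0.52 log units; beyond the scatter) and a 3.4-fold lower number from compound 1 to compound 4 (0.54 log units; beyond the scatter) as its steps, so chlorine on the aryl ring does not by itself set the level: compound 1, with its 4-chlorophenyl group, stands higher. Nothing available here explains why these two different groups land together.

Every group shown on this aromatic nitrogen is a substituted phenyl, so it remains open whether a ring is needed there at all, which a short alkyl chain or an amine-bearing chain could test. A 3,5-dimethoxyphenyl group would show whether the level follows the two-group pattern or the chlorine atoms.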